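Replacing a ring nitrogen in a triaryl pyridine series

This account rests on a few compounds, and the source may have more. Where it says the series, first, only, none or still open, it means among the compounds named here.

The shared core of compound 1 `Oc1ccc(-c2cc(-c3cccnc3)nc(-c3ccccc3Cl)c2)cc1` carries three aromatic groups, and the series was examined in an ADME assay on HEK293 cells (Homo sapiens) for cytotoxicity, read by CCK-8 assay and cell counting, with a stated time of 2 days; on this read-out lower numbers stand for stronger inhibition and higher numbers for weaker inhibition. For compound 1 this assay gives "not determined" (no result reported), so it stands without a value of its own. Two relatives give the only measured points: compound 2 `Oc1cccc(-c2cc(-c3ccc(Cl)cc3)nc(-c3cccs3)c2)c1` gives 11800 nM in this assay, and compound 3 `Oc1ccc(-c2cc(-c3ccsc3)nc(-c3cccc(Cl)c3)c2)cc1` gives 2670 nM in this assay. Compound 4 `Oc1ccc(-c2cc(-c3ccccc3)nc(-c3ccccc3Cl)c2)cc1` is the unmeasured partner of compound 1; it differs from compound 1 by a single change, (phenyl in place of pyridin-3-yl on an aromatic carbon). With no measured value for compound 1, the size of this step in this assay cannot be read from the data, and it is expected to fall within the scatter or only modestly beyond it, in either direction. Because compound 2 gives 11800 nM and compound 3 gives 2670 nM in this assay, compound 4 is expected to give 5000 nM in this assay, with a likely range from 1500 nM to 20000 nM.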

Compound 4, half-maximal inhibitory concentration: 3930 nM
Beside the measured number, compound 4's estimate is 1.3-fold (0.10 log units) above it, within the range that was stated.
By their numbers in this assay, from the lowest: compounds 3 and 4 (each within the scatter of the next); then compound 2.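

Within the data shown here, no step from compound 1 to compound 4 can be read from these results. The compounds shown leave open whether phenyl in place of pyridin-3-yl changes the value at all in this assay. No supporting measurement bears on the value of compound 4.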